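Trimming the methoxycarbonyl group from compound 1

The compounds below may be only part of what the source reports. "The series", "measured", "known", "first", "only" and "open" are said of these compounds alone.

Of the compounds shown here, three have so far been tested in a functional assay on NCI-H460 cells (Homo sapiens) for cytotoxicity, read by MTT assay, with a stated time of 68 h; a lower number here means a stronger inhibitor, a higher number a weaker inhibitor. Compound 1, `COC(=O)c1ccc(-c2cccc(NC(=O)C(Cl)Cl)c2)cc1`, gives there only a limit of the assay, > 50000 nM. Compound 2, `COc1ccccc1-c1cc(NC(=O)C(Cl)Cl)cc(-c2ccccc2OC)c1`, likewise reaches only a limit, > 30000 nM. Compound 3, `COc1ccc(-c2cc(NC(=O)C(Cl)Cl)cc(-c3ccc(OC)cc3)c2)cc1`, also stops at a limit, > 30000 nM. Compound 1 therefore stands among three compounds for which no number is known at all: its own value sits at the limit of > 50000 nM in this assay, at which 1 of the 3 values shown sits, while the other two sit at the limit of > 30000 nM in this assay, at which 2 of the 3 values shown sit. Every value is a limit. Among the measured compounds shown here, no step between measured compounds can be worked out from these data.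

Compound 4, `O=C(Nc1cccc(-c2ccccc2)c1)C(Cl)Cl`, is the untested partner of compound 1. The change is hydrogen in place of methoxycarbonyl on an aromatic carbon. For the measured compounds named here, with compound 1 at a limit and no measured step pointing in either direction, no shift beyond the usual scatter of this assay is expected, and the most likely outcome is once more a limit rather than a number. Compound 4 is therefore estimated at 50000 nM, with an expected range from 10000 nM to 200000 nM. The expected step is a number no higher from compound 1 to compound 4 (the limit leaves the size open).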

Compound 4, half-maximal inhibitory concentration: 20200 nM
For compound 4 the middle estimate is 2.5-fold (0.39 log units) above the measured one; measured number inside the range.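

Placing hydrogen where the methoxycarbonyl group stood, para to a large group, gives an at least 2.4-fold lower number from compound 1 to compound 4 (0.39 log units; beyond the scatter) in this assay. Among the compounds shown here, the methoxycarbonyl group is therefore not required at this position for a measurable effect on these cells, and compound 4 is the only one of the four compounds with a number rather than a limit. The true size of this step stays open because compound 1 gives only a limit: the limit of > 50000 nM in this assay, at which 1 of the 4 values shown sits.

Compound 2 and compound 3 differ from compound 4 in more than one place, so steps involving them cannot be read. From the compounds shown here alone, how a carboxylic acid, an amine or a hydroxyl group at this position would compare with the hydrogen of compound 4 remains open.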